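Piperidine for morpholine on the amide of compound 2

This account rests on a few compounds, and the source may have more. Where it says the series, first, only, none or still open, it means among the compounds named here.

Two compounds share a bis-sulfonyl core and a piperidine amide, and both have been run in a functional assay on BXPC-3 cells (Homo sapiens) for inhibition, read by MTT assay, with a stated time of 7 days; on this read-out higher numbers stand for weaker inhibition and lower numbers for stronger inhibition. Compound 1 `CC(C)S(=O)(=O)c1ccc(S(=O)(=O)N2CCC[C@@H](C(=O)N3CCC(F)(F)CC3)C2)cc1` gives 50 nM in this assay. Compound 2 `CCN(CC)S(=O)(=O)c1ccc(S(=O)(=O)N2CCC[C@@H](C(=O)N3CCOCC3)C2)cc1` gives 790 nM in this assay, the highest of the two numbers; its nearest neighbour is compound 1, whose number is lower by a margin that lies beyond the scatter. These two compounds differ in more than one place, so their gap cannot be traced to a single change.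

Compound 3 `CCN(CC)S(=O)(=O)c1ccc(S(=O)(=O)N2CCC[C@@H](C(=O)N3CCC(COC)CC3)C2)cc1` is not yet measured. It differs from compound 2 by a single change, (4-(methoxymethyl)piperidin-1-yl in place of morpholin-4-yl on a carbonyl carbon), which keeps a six-membered saturated ring and one hydrogen-bond acceptor but moves the oxygen out of the ring into a methoxymethyl side chain.

Among the measured compounds shown here, no measured pair shows this change on its own, so the size of the step is open. A modest move toward a lower number is expected for compound 3, since compound 1, which also carries a substituted piperidine on the carbonyl, gives 50 nM. The expected step of a 2.0-fold lower number from compound 2 to compound 3 (0.30 log units; within the scatter) is small. Compound 3 is estimated at 400 nM, within a range of 100 nM to 1500 nM.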

Compound 3, half-maximal inhibitory concentration: 1360 nM
Compound 3: middle estimate off by 3.4-fold (0.53 log units), on the low side; the measured number falls inside the stated range.
By their numbers in this assay, from the lowest: compound 1; then compounds 2 and 3 (each within the scatter of the next).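

In this assay, among the compounds shown here, putting 4-(methoxymethyl)piperidin-1-yl in place of morpholin-4-yl on the carbonyl carbon gives a 1.7-fold higher number from compound 2 to compound 3 (0.24 log units; within the scatter), the only reading of this change on its own. With the rest of compound 2 held fixed, moving the oxygen out of the ring into a methoxymethyl side chain therefore leaves the number within the scatter, and carrying a substituted piperidine on this carbonyl does not by itself set compound 3 apart from compound 2. Nothing on hand gives a reason for this result.

The compounds shown leave open how a plain piperidin-1-yl, or a piperidine bearing a hydroxyl group or a carboxylic acid in place of the methoxymethyl side chain, would read on this carbonyl. On these data alone, compound 1 gives 50 nM in this assay, yet it differs from compound 2 and from compound 3 in more than one place, so which of its differences goes with that number also stays open.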